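From a Ring to an Open Chain on Compound 2

A few compounds are considered here, and "the series" means these few. Any claim that something is new, unique, unknown or untested is made for them only; others in the source may bear on it.

In a functional assay on SK-BR-3 cells (Homo sapiens) for antiproliferative activity (a higher number here means a weaker inhibitor, a lower number a stronger inhibitor), compound 1 `CC(=O)Oc1ccc(C(=O)Nc2cc3ccc(OCC4CCCN(C)C4)c(C)c3oc2=O)cc1CC=C(C)C` gives 740 nM, compound 3 `CC(C)=CCc1cc(C(=O)Nc2cc3ccc(OCC4CCN(C)C4)c(C)c3oc2=O)ccc1O` gives 920 nM and compound 2 `CC(C)=CCc1cc(C(=O)Nc2cc3ccc(OCC4CCCN(C)C4)c(C)c3oc2=O)ccc1O` gives 1300 nM, which lies within the scatter of both others. Compound 4 `CCN(C)CCCOc1ccc2cc(NC(=O)c3ccc(O)c(CC=C(C)C)c3)c(=O)oc2c1C` carries 2-(ethyl(methyl)amino)ethyl in place of 1-methylpiperidin-3-yl on a saturated chain carbon bound to an oxygen on an aromatic ring. The closest measured change, at this same place, is a 1.4-fold lower number from compound 2 to compound 3 (0.15 log units; within the scatter). The change elsewhere, a 1.8-fold higher number from compound 1 to compound 2 (0.24 log units; within the scatter), is equally modest. Within the data shown here, no measured compound has a side chain without a ring, so the estimate rests on these small steps alone. The expected step is a 1.3-fold lower number from compound 2 to compound 4 (0.11 log units; within the scatter), which means none beyond the scatter. For compound 4 the estimated value is 1000 nM, with an expected range of 400 nM to 2500 nM.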

Compound 4, half-maximal inhibitory concentration: 730 nM
The estimate for compound 4 lay 1.4-fold (0.14 log units) above the measured number, and the stated range covers the measured number.
By their numbers in this assay, from the lowest: compounds 4, 1, 3 and 2 (each within the scatter of the next).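

In this assay the group on a saturated chain carbon bound to an oxygen on an aromatic ring need not carry a ring: with a 1.8-fold lower number from compound 2 to compound 4 (0.25 log units; within the scatter) and a 1.3-fold lower number from compound 3 to compound 4 (0.10 log units; within the scatter) as the steps, the open 2-(ethyl(methyl)amino)ethyl group stands level with both 1-methylpiperidin-3-yl and 1-methylpyrrolidin-3-yl. The earlier compounds had shown only one ring exchanged for another at this place. Nothing available here gives a reason for this result.

From the compounds shown here alone, whether a carboxylic acid, a primary amine or a longer chain at this place would stay level remains open. So does whether the open chain would stay level with acetyl on the oxygen on the aromatic ring.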